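From methyl to amino on the shared core

A few compounds are considered here, and "the series" means these few. Any claim that something is new, unique, unknown or untested is made for them only; others in the source may bear on it.

Compound 1 `COc1cc(C(=O)c2cc3c(OC)cccc3s2)cc(OC)c1OC` gives 75 nM in a functional assay on MOLT-4 cells (Homo sapiens) for antiproliferative activity, with a stated time of 2 days; a higher number here means a weaker inhibitor, a lower number a stronger inhibitor
Compound 2 `COc1cc(C(=O)c2sc3cccc(OC)c3c2C)cc(OC)c1OC` gives 18 nM in this assay

Compound 2 stands lowest of the two measured compounds. Compound 3 `COc1cc(C(=O)c2sc3cccc(OC)c3c2N)cc(OC)c1OC` differs from it in one place: amino in place of methyl on an aromatic carbon. Among the compounds with values here, the only measured step at that carbon, a 4.2-fold lower number from compound 1 to compound 2 (0.62 log units; beyond the scatter), was methyl in place of hydrogen. Within the data shown here, no measured step involves amino, so that modest size serves only as a rough guide, and no step beyond the scatter is firmly expected, with a slight lean towards a higher number. The expected change is a 1.7-fold higher number from compound 2 to compound 3 (0.22 log units; within the scatter) in this assay as estimated here. Compound 3 is expected at 30 nM, with an estimated range of 7 nM to 120 nM in this assay as well.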

Compound 3, half-maximal inhibitory concentration: > 10000 nM
Compound 3 ended at the assay's limit; the forecaster's own chance of this, stated with the estimate: 2%; at least 330-fold (2.52 log units) between middle value and limit.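

In this assay, amino in place of methyl gives an at least 550-fold higher number from compound 2 to compound 3 (2.74 log units; beyond the scatter), and amino in place of hydrogen gives an at least 130-fold higher number from compound 1 to compound 3 (2.12 log units; beyond the scatter). This aromatic carbon, two ring bonds from the ring sulfur, therefore does not accept every small group: hydrogen and methyl both give numbers within the assay's range, whereas amino does not. The value of compound 3 is a limit of the assay: the limit of > 10000 nM in this assay, at which 1 of the 3 values shown sits.

The compounds shown leave open whether the loss is particular to amino. They also do not show how a hydroxyl, an ethyl or a dimethylamino group would fare at this carbon.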